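The source may hold more compounds than are shown below. What is called first, only, known or untested is meant among the compounds shown, and "the series" means these compounds.

Measured in a functional assay on DU-145 cells (Homo sapiens) for inhibition; a lower number here means a stronger inhibitor of growth, a higher number a weaker inhibitor of growth:
- compound 1 `O=S(=O)(/C=C/c1ccc(F)cc1)Cc1ccc(Nc2ncnc3ccccc23)cc1`: 300 nM
- compound 2 `O=S(=O)(/C=C/c1ccc(Br)cc1)Cc1ccc(Nc2ncnc3ccccc23)cc1`: 55000 nM
- compound 3 `O=S(=O)(/C=C/c1ccc(O)cc1)Cc1ccc(Nc2ncnc3ccccc23)cc1`: 19000 nM

Of these three, compound 2 gives the highest number, making it the weakest inhibitor of growth. Compound 4 `O=S(=O)(/C=C/c1ccc(Br)cc1)Cc1ccc(Nc2ncnc3ccc(Br)cc23)cc1` differs from compound 2 by bromo in place of hydrogen on an aromatic carbon. Within the data shown here, no measured step touches that place. The measured exchanges lie elsewhere: a 180-fold higher number from compound 1 to compound 2 (2.26 log units; beyond the scatter) and a 63-fold higher number from compound 1 to compound 3 (1.80 log units; beyond the scatter) are large, while a 2.9-fold lower number from compound 2 to compound 3 (0.46 log units; beyond the scatter) is modest. They show that one aromatic exchange can move this read-out widely, but they give no direction for the new bromo. No clear step beyond the scatter is therefore expected, and the expected change is a 1.4-fold lower number from compound 2 to compound 4 (0.14 log units; within the scatter). For compound 4 the estimate is 40000 nM, with an expected range of 8000 nM to 150000 nM.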

Compound 4, concentration for 50% growth inhibition: 3000 nM
The estimate for compound 4 lay 13-fold (1.12 log units) above the measured number; measured number outside the range, below it.
By their numbers in this assay, from the lowest: compound 1; then compound 4; then compound 3; then compound 2.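

In this assay, bromo in place of hydrogen on an aromatic carbon of the ring in the fused system gives an 18-fold lower number from compound 2 to compound 4 (1.26 log units; beyond the scatter), a large step. Among these compounds, this place, untouched by the earlier steps, therefore also moves the read-out, and here a bromo lowers the number. Nothing available explains this step.

As far as these compounds go, the step is known only with the bromo of compound 2 kept on the other aromatic ring, so whether it holds alongside the fluoro of compound 1 stays open. From the compounds shown here alone, whether an amine or a methoxy group at this place would act like bromo also remains open.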